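Furan-2-yl in place of methyl: stability notes

This account rests on a few compounds, and the source may have more. Where it says the series, first, only, none or still open, it means among the compounds named here.

In an ADME assay on cells (Hepatocyte, Mus musculus) for metabolic stability (a lower number here means that the compound disappears faster, a higher number that the compound lasts longer), compound 1 `O=C(OC1CCC(CN2CCN(c3cc(=O)c4cc(C(F)(F)F)cc([N+](=O)[O-])c4s3)CC2)CC1)c1ccccc1` gives 0.903 h and compound 2 `Cc1ccc(C(=O)OC2CCC(CN3CCN(c4cc(=O)c5cc(C(F)(F)F)cc([N+](=O)[O-])c5s4)CC3)CC2)cc1` gives 0.202 h. Compound 3 `CC(=O)OC1CCC(CN2CCN(c3cc(=O)c4cc(C(F)(F)F)cc([N+](=O)[O-])c4s3)CC2)CC1` gives < 0.15 h, which is a limit of the assay and not a number. The comparison therefore starts from a limit.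

Compound 4 `O=C(OC1CCC(CN2CCN(c3cc(=O)c4cc(C(F)(F)F)cc([N+](=O)[O-])c4s3)CC2)CC1)c1ccco1` carries furan-2-yl in place of methyl on a carbonyl carbon. For the measured compounds named here, three measured steps bear on this change. Methyl in place of phenyl at that carbon gave an at least 6.0-fold lower number from compound 1 to compound 3 (0.77 log units; beyond the scatter), and the change to compound 4 runs the opposite way, from methyl to an aromatic ring. A single methyl on an aromatic carbon gave a 4.5-fold lower number from compound 1 to compound 2 (0.65 log units; beyond the scatter), so the number in this series depends on more than the presence of an aromatic ring. The remaining step, an at least 1.3-fold lower number from compound 2 to compound 3 (0.12 log units; that floor lies within the scatter), has a floor within the scatter, so an aromatic ring at that carbon does not guarantee clear separation from compound 3.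

A modest rise in this assay is therefore expected, and it may prove small. The expected step is an at least 2.3-fold higher number from compound 3 to compound 4 (0.36 log units; beyond the scatter). The estimate for compound 4 is 0.35 h, with an expected range of 0.15 h to 0.9 h.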

Compound 4, half-life: < 0.075 h
Compound 4 was reported as a limit; the forecaster's own chance of this, stated with the estimate: 20%; middle value at least 4.6-fold (0.66 log units) from the limit.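

Compound 4 stands in this assay only as a limit, not as a number: the limit of < 0.075 h in this assay, at which 1 of the 4 values shown sits.

With furan-2-yl in place of phenyl on the carbonyl carbon the result is an at least 12-fold lower number from compound 1 to compound 4 (1.08 log units; beyond the scatter), and with furan-2-yl in place of 4-methylphenyl it is an at least 2.6-fold lower number from compound 2 to compound 4 (0.43 log units; beyond the scatter), so the presence of an aromatic ring on this carbon does not by itself keep the number up, and the identity of the ring matters. Compound 3 is also reported as a limit, and the step to compound 4 cannot be read from the two limits: the limit of < 0.15 h in this assay, at which 1 of the 4 values shown sits.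

On these data alone, whether furan-2-yl and methyl differ at all on this carbonyl carbon stays open, with both compounds resting on limits. Also open, as far as these compounds go, is whether thiophen-2-yl, as another five-membered aromatic ring with one hetero atom, or cyclohexyl, as a ring that is not aromatic, would sit on this carbon nearer to compound 1 or nearer to compound 4.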